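A Second Bromine on a Weakly Active Core

This account rests on a few compounds, and the source may have more. Where it says the series, first, only, none or still open, it means among the compounds named here.

Within the data shown here, compound 1 `N#C/C(=C\C=C(/Cl)c1ccc(Br)cc1)C(=O)c1c[nH]c2ccccc12` is the only member of this small set with a numerical result: in a functional assay on MCF7 cells (Homo sapiens) for cytotoxicity, read by sulforhodamine B assay, with a stated time of 48 h (a lower number here means a stronger inhibitor of growth, a higher number a weaker inhibitor of growth), compound 1 gives 81500 nM. Compound 2 `COc1ccc(/C(Cl)=C/C=C(\C#N)C(=O)c2c[nH]c3ccccc23)cc1OC` differs from it in more than one place, and that difference between the two cores is not broken down here. In this assay compound 2 reaches only a limit of the assay, > 100000 nM. Compound 3 `COc1ccc(/C(Cl)=C/C=C(\C#N)C(=O)c2c[nH]c3ccc(Br)cc23)cc1OC` carries a bromo in place of hydrogen on an aromatic carbon, (bromo in place of hydrogen on an aromatic carbon), and in this assay compound 3 also sits at a limit, > 100000 nM. The step that the two limits leave unreadable from compound 2 to compound 3 is therefore of unreadable size, because the limit of > 100000 nM in this assay, at which 2 of the 3 values shown sit, hides both ends of it.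

Compound 4 `N#C/C(=C\C=C(/Cl)c1ccc(Br)cc1)C(=O)c1c[nH]c2ccc(Br)cc12` carries the same change on the core of compound 1, (bromo in place of hydrogen on an aromatic carbon), at a place described in identical words. Among the measured compounds shown here, with the only measured example of this change unreadable, the expectation for compound 4 rests on compound 1 alone, and the step of a 1.1-fold lower number from compound 1 to compound 4 (0.04 log units; within the scatter) is expected to stay small. Compound 4 is thus estimated at 75000 nM, between 25000 nM and 200000 nM.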

Compound 4, concentration for total growth inhibition: > 100000 nM
Compound 4 was reported as a limit; the forecaster's own chance of this, stated with the estimate: 35%; middle value at least 1.3-fold (0.12 log units) away from the limit.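

In this assay compound 4 gives > 100000 nM, which is a limit of the assay and not a number. Placing a bromo on this aromatic carbon therefore gives only a lower bound on the step, an at least 1.2-fold higher number from compound 1 to compound 4 (0.08 log units; that floor lies within the scatter), so the result does not establish a real loss of growth inhibition, nor does it give the true size of the step. The same change on the other core, from compound 2 to compound 3, cannot be read at all, so the effect of the change cannot be compared between the two cores, because too many results stop at the same limit: the limit of > 100000 nM in this assay, at which 3 of the 4 values shown sit.

On these data alone, it remains open how far the bromo moves the result on the core of compound 1, and whether it acts in the same direction on both cores. Also open, as far as these compounds go, is how another group at this place, such as an amine or a carboxylic acid, would behave in this assay.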